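This account rests on a few compounds, and the source may have more. Where it says the series, first, only, none or still open, it means among the compounds named here.

Three related compounds have been tested in a functional assay on HeLa cells (Homo sapiens) for antiproliferative activity, read by MTT assay, with a stated time of 72 h; a lower number here means a stronger inhibitor, a higher number a weaker inhibitor. Compound 1 `O=c1c(SC(=S)N2CCCC2)coc2ccc(Cl)cc12` gives 16300 nM in this assay. Compound 3 `O=c1c(SC(=S)N2CCCC2)coc2ccccc12` differs from compound 1 by one change, (hydrogen in place of chloro on an aromatic carbon), and in this assay compound 3 gives 3800 nM. That change made a 4.3-fold lower number from compound 1 to compound 3 (0.63 log units; beyond the scatter). Compound 2 `O=c1c(Cl)c(CSC(=S)N2CCOCC2)oc2ccccc12` has a different core; how its core differs from that of compound 1 is not broken down here. In this assay compound 2 gives 4500 nM. Its number and that of compound 3 lie within the usual scatter of each other, so nothing separates them, while the number of compound 1 lies beyond the scatter and is the higher one.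

Compound 4 `O=c1cc(CSC(=S)N2CCOCC2)oc2ccccc12` is still to be measured. It differs from compound 2 by hydrogen in place of chloro on an aromatic carbon. Among the measured compounds shown here, this is the same kind of change as the one from compound 1 to compound 3, but not the same: in compound 1 the chloro sits on a six-membered aromatic ring of carbon only, whereas in compound 2 it sits on a six-membered aromatic ring with 1 oxygen, ortho to a group of 1 heavy atom, ortho to a large group, two atoms from the ring oxygen. For the measured compounds named here, because the single measured example of this kind of change gave a 4.3-fold lower number from compound 1 to compound 3 (0.63 log units; beyond the scatter), a lower number is also expected for compound 4, though with less confidence given the different surroundings, and the step from compound 2 to compound 4 is expected to be a 1.5-fold lower number from compound 2 to compound 4 (0.18 log units; within the scatter). In this assay compound 4 is estimated at 3000 nM, with a likely range from 900 nM to 10000 nM.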

Compound 4, half-maximal inhibitory concentration: 35600 nM
Compound 4: middle estimate off by 12-fold (1.07 log units), on the low side; the whole stated range lies below it.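

In this assay, putting hydrogen in place of chloro on the aromatic carbon of the ring with 1 oxygen gave a 7.9-fold higher number from compound 2 to compound 4 (0.90 log units; beyond the scatter), so on this core losing the chloro left a weaker inhibitor. The earlier step with this kind of change ran the opposite way, and the two steps clearly disagree: the same change on two cores in this assay, a 4.3-fold lower number (0.63 log units; beyond the scatter) from compound 1 to compound 3 and a 7.9-fold higher number (0.90 log units; beyond the scatter) from compound 2 to compound 4, 34-fold (1.53 log units) apart, beyond the scatter of two such steps. This shows that neither the size nor the direction of this change carries from one core to another in this series, so a step measured on one core is a poor guide to the other; it does not show why, since the two pairs differ both in the ring that bears the chloro and in the rest of the molecule, and a single pair on each core cannot separate these differences.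

The compounds shown leave open whether the gain from chloro on the core of compound 2 is specific to chlorine, or whether fluoro, bromo or a methyl group on that same carbon would also give a number close to that of compound 2. They also leave open whether the same change on a third core would follow either of the two steps, or neither.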